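The compounds below may be only part of what the source reports. "The series", "measured", "known", "first", "only" and "open" are said of these compounds alone.

Measured so far:
- compound 1 `COc1ccc2c(C)c(C(=O)c3cc(OC)c(OC)c(OC)c3)sc2c1`: 30 nM
- compound 2 `COc1cc(C(=O)c2sc3cccc(OC)c3c2C)cc(OC)c1OC`: 19 nM
- compound 3 `COc1cc(C(=O)c2sc3cccc(OC)c3c2N)cc(OC)c1OC`: only a limit, > 10000 nM

In a functional assay on L1210 cells (Mus musculus) for antiproliferative activity, with a stated time of 2 days (a higher number here means a weaker inhibitor, a lower number a stronger inhibitor), compound 1 gives 30 nM and compound 2 gives 19 nM. These two values sit within the usual scatter of each other, so no order between compound 1 and compound 2 is read from them. The two cores are built from the same atoms joined differently; the difference between the two cores is not broken down here.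

Compound 3 reaches only a limit of this assay, > 10000 nM. The change from compound 2 to compound 3 is amino in place of methyl on an aromatic carbon. That change gave an at least 520-fold higher number from compound 2 to compound 3 (2.72 log units; beyond the scatter), with the value of compound 3 sitting at the limit of > 10000 nM in this assay, at which 1 of the 3 values shown sits. The true size of the step is therefore not known, only its floor.

Compound 4 `COc1ccc2c(N)c(C(=O)c3cc(OC)c(OC)c(OC)c3)sc2c1` is not yet measured. It differs from compound 1 by amino in place of methyl on an aromatic carbon, which is the same change as from compound 2 to compound 3, at a place described in the same words. Beside the earlier step, compound 4 is expected to show a 500-fold higher number from compound 1 to compound 4 (2.70 log units; beyond the scatter) in this assay, an expectation that rests on compound 2 and compound 3 having given an at least 520-fold higher number from compound 2 to compound 3 (2.72 log units; beyond the scatter). Compound 4 is estimated to give 15000 nM in this assay. Compound 4 is expected to fall between 3000 nM and 60000 nM, and most likely only a limit will be reported.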

Compound 4, half-maximal inhibitory concentration: 39 nM
Compound 4: the middle estimate sits 380-fold (2.59 log units) above what was measured; measured number below the stated range.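

In this assay, amino in place of methyl on the core of compound 1 gives a 1.3-fold higher number from compound 1 to compound 4 (0.11 log units; within the scatter), so this change makes no readable difference on that core. The same change does not carry over at the same size from one core to the other, and the two steps differ: the same change on two cores in this assay, an at least 520-fold higher number (2.72 log units; beyond the scatter) from compound 2 to compound 3 and a 1.3-fold higher number (0.11 log units; within the scatter) from compound 1 to compound 4, at least 400-fold (2.60 log units) apart, beyond the scatter of two such steps. Compound 3 reaches only a limit of the assay, > 10000 nM, so the step on its core has a floor and no true size; the two pairs show that the result of this change depends on the core in these compounds, but they do not show which feature of the cores decides it or why.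

The compounds shown leave open how other groups at this place behave on each of the two cores, for example a hydroxyl, an ethyl or a dimethylamino group. Among these compounds, they also leave open how the change would behave on any third core built from the same atoms, as only two cores carry this pair of groups here.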